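The source may report more compounds than this note shows. Statements on the series, on what has been measured and on what is new or still open speak of the compounds shown alone.

Compound 3 `Nc1nn(C(=O)Nc2ccc(Cc3ccccc3)cc2)c2ccccc12` gives 530 nM in a functional assay on SF-295 cells (Homo sapiens) for inhibition, read by sulforhodamine B assay, with a stated time of 48 h (a higher number here means a weaker inhibitor of growth, a lower number a stronger inhibitor of growth), the lower of the two numbers in hand. Compound 1 `O=C(Nc1ccccc1OC(F)(F)F)Nc1n[nH]c2ccccc12` gives 39000 nM in this assay, a gap from compound 3 that lies beyond the scatter. Compound 2 `O=C(Nc1ccc(Cc2ccccc2)cc1)Nc1nn(C(=O)Nc2ccc(Cc3ccccc3)cc2)c2ccccc12` reaches only a limit in this assay, > 100000 nM; this is the limit (the limit of > 100000 nM in this assay, at which 1 of the 3 values shown sits). Compound 4 `CCCCOc1ccc(NC(=O)n2nc(N)c3ccccc32)cc1` is not yet measured. The change from compound 3 is butoxy in place of benzyl on an aromatic carbon. Among the compounds with values here, no measured pair shows this change, so the size of the step is open; a modest move toward a weaker inhibitor, close to the edge of the scatter, is expected, a 1.9-fold higher number from compound 3 to compound 4 (0.28 log units; within the scatter). Compound 4 is therefore estimated at 1000 nM in this assay, with a range from 300 nM to 4000 nM.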

Compound 4, concentration for 50% growth inhibition: 21700 nM
Estimate against measurement, compound 4: 22-fold (1.34 log units) below; the whole stated range lies below it.
By their numbers in this assay, from the lowest: compound 3; then compounds 4 and 1 (each within the scatter of the next). At a limit, above all of these: compound 2.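

Butoxy in place of benzyl gives a 41-fold higher number from compound 3 to compound 4 (1.61 log units; beyond the scatter) in this assay and so shows that this place, para to a large group, is sensitive to the change. Since a ring leaves and an oxygen-bearing open chain enters, this single pair cannot separate the loss of the ring from the gain of the oxygen. Nothing in hand accounts for the size of this step.

Still open, as far as these compounds go, is where a phenoxy group, which keeps a ring and carries an oxygen, would fall relative to compound 3 and compound 4 in this assay and how a pentyl chain, which has no oxygen, would compare with butoxy.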